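The compounds below may be only part of what the source reports. "The series", "measured", "known", "first", "only" and "open" are said of these compounds alone.

Series notes. In a functional assay on G-361 cells (Homo sapiens) for cytotoxicity, read by sulforhodamine B assay (a lower number here means a stronger inhibitor of growth, a higher number a weaker inhibitor of growth), compound 1 `Cc1nc(NCc2ccco2)c2cnn(-c3ccccc3)c2n1` gives > 100000 nM, which is a limit of the assay and not a number. Compound 2 `CCN(CC)c1nc(C)nc2c1cnn2-c1ccccc1` gives in this assay > 100000 nM, likewise a limit of the assay. Within the data shown here, the single measured step, a step that the two limits leave unreadable from compound 1 to compound 2, cannot be sized because of the limit of > 100000 nM in this assay, at which 2 of the 2 values shown sit. Compound 2 therefore stands only at a limit in this assay, with no numerical position within the series.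

Compound 3 `CCNc1nc(C)nc2c1cnn2-c1ccccc1` differs from compound 2 by hydrogen in place of ethyl on a nitrogen on an aromatic ring. Among the measured compounds shown here, no measured step bears on this change in a readable way: the only one available, a step that the two limits leave unreadable from compound 1 to compound 2, stays unreadable because of the limit of > 100000 nM in this assay, at which 2 of the 2 values shown sit. Compound 3 is expected to remain at or near that limit, so the estimated step that the limit leaves unreadable from compound 2 to compound 3 means no change beyond the scatter. Compound 3 is estimated in this assay at 150000 nM, with a range from 30000 nM to 1000000 nM.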

Compound 3, concentration for total growth inhibition: > 100000 nM
Compound 3 ended at the assay's limit (the forecaster's own chance of this, stated with the estimate: 85%); the middle value does not contradict the limit.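

Among these compounds, no step among compound 1, compound 2 and compound 3 can be read in this assay, because all three values are limits of the assay and not numbers: the limit of > 100000 nM in this assay, at which 3 of the 3 values shown sit.

Whether any amino group on the shared core gives a readable value in this assay remains open with the compounds shown.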